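Weak cytotoxic pair and a methoxy variant on the core

The source may report more compounds than this note shows. Statements on the series, on what has been measured and on what is new or still open speak of the compounds shown alone.

The measured compounds:
compound 1 `O=C(CN[C@H]1CCN(S(=O)(=O)Cc2ccccc2)C1)N1CCN(Cc2cccc(Cl)c2)CC1` gives 8600 nM in a functional assay on K562 cells (Homo sapiens) for cytotoxicity, read by MTT assay, with a stated time of 48 h; on this read-out higher numbers stand for weaker inhibition and lower numbers for stronger inhibition;
compound 2 `O=C(CN[C@H]1CCN(S(=O)(=O)Cc2ccccc2)C1)N1CCN(Cc2ccc(Cl)cc2)CC1` gives 9200 nM in this assay.

Compound 2 stands at the highest of the two numbers, but its nearest neighbour is compound 1, and the step of a 1.1-fold higher number from compound 1 to compound 2 (0.03 log units; within the scatter) lies within the scatter, so the two compounds cannot be told apart on these numbers.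

Compound 3 `COc1cccc(CN2CCN(C(=O)CN[C@H]3CCN(S(=O)(=O)Cc4ccccc4)C3)CC2)c1` is the unmeasured variant. Its difference from compound 2 is 3-methoxyphenyl in place of 4-chlorophenyl on a saturated chain carbon bound to an amine nitrogen in a ring.

Among the measured compounds shown here, only one measured step bears on this change, and only loosely: the step of a 1.1-fold higher number from compound 1 to compound 2 (0.03 log units; within the scatter), which moves the chlorine on the same ring and changes nothing beyond the scatter. No measured step swaps the chlorine for the methoxy group, so that part of the change is unsupported by the numbers shown. On this basis the account expects no step beyond the scatter from compound 2 to compound 3, and it notes that the uncertainty is wider than for the chlorine shift.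

The step from compound 2 to compound 3 is expected to be a 1.0-fold lower number from compound 2 to compound 3 (0.01 log units; within the scatter).

In this assay compound 3 is estimated at 9000 nM, with a range of 3500 nM to 25000 nM.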

Compound 3, half-maximal inhibitory concentration: 60800 nM
Estimate against measurement, compound 3: 6.8-fold (0.83 log units) below; the whole stated range lies below it.
By their numbers in this assay, from the lowest: compounds 1 and 2 (each within the scatter of the next); then compound 3.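

The aromatic ring on a saturated chain carbon bound to an amine nitrogen in a ring had seemed indifferent to its substituent while only the chlorine moved, but in this assay this position proves sensitive to which group it carries, with a 6.6-fold higher number from compound 2 to compound 3 (0.82 log units; beyond the scatter) in the change from 4-chlorophenyl to 3-methoxyphenyl. Among the compounds shown here, the sharper comparison is a 7.1-fold higher number from compound 1 to compound 3 (0.85 log units; beyond the scatter), where methoxy in place of chloro on an aromatic carbon is the only change, so the weaker inhibition follows the exchange of chloro for methoxy and does not depend on the move from 4-chlorophenyl to 3-methoxyphenyl alone. Nothing among the available data accounts for this loss.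

The compounds shown leave open whether methoxy itself weakens inhibition or whether chloro supports it, a question that an unsubstituted phenyl or a fluoro group at this place would bear on. They also leave open how a hydroxy group, a dimethylamino group or a carboxylic acid on this ring would compare with the chloro pair, and whether any group here could give a clearly lower number.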